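Thiol-ether variation on a quinazoline-type antiproliferative pair

The source may report more compounds than this note shows. Statements on the series, on what has been measured and on what is new or still open speak of the compounds shown alone.

Measured so far:
compound 1, `Cc1ccc(-c2nc3ccc(Cl)cc3c(=S)n2N)cc1`, gives 9.25 ug/mL in a functional assay on MCF7 cells (Homo sapiens) for antiproliferative activity, read by MTT assay, with a stated time of 48 h; on this read-out higher numbers stand for weaker inhibition and lower numbers for stronger inhibition.
compound 2, `CSc1nc(-c2ccc(C)cc2)nc2ccc(Cl)cc12`, gives 8.64 ug/mL in this assay.

On these two numbers compound 2 and compound 1 stand within the scatter of each other, so neither is set apart. Compound 3, `Cc1ccc(-c2nc(SCCO)c3cc(Cl)ccc3n2)cc1`, differs from compound 2 by hydroxymethyl in place of hydrogen on a saturated chain carbon bound to a sulfur. For the measured compounds named here, no measured pair shows the effect of such a change, and the shared core with its substituents is kept. The expected step of a 1.0-fold higher number from compound 2 to compound 3 (0.02 log units; within the scatter) is none beyond the scatter. Compound 3 is therefore estimated at 9 ug/mL in this assay, with a range of 4.5 ug/mL to 18 ug/mL.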

Compound 3, half-maximal inhibitory concentration: 3.76 ug/mL
Beside the measured number, compound 3's estimate is 2.4-fold (0.38 log units) above it; the whole stated range lies above it.
By their numbers in this assay, from the lowest: compound 3; then compounds 2 and 1 (each within the scatter of the next).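

In this assay the change from methylsulfanyl to (2-hydroxyethyl)sulfanyl gives a 2.3-fold lower number from compound 2 to compound 3 (0.36 log units; beyond the scatter) and this modest step lies beyond the scatter. The position on sulfur therefore accepts hydroxymethyl in place of hydrogen on the saturated chain carbon without loss, and the read-out responds to a change at this place. No supporting data explain this step.

Still open, on these data alone, is whether the step follows the hydroxyl or the longer chain, which an unsubstituted ethyl group would separate. As far as these compounds go, how an amine or a carboxylic acid at the chain end would read also stays open.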